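Sulfonate ester series: chloroacetamide to pentylurea at the aniline

This account rests on a few compounds, and the source may have more. Where it says the series, first, only, none or still open, it means among the compounds named here.

Measured so far in a functional assay on MCF7 cells (Homo sapiens) for antiproliferative activity, read by sulforhodamine B assay, with a stated time of 48 h; a higher number here means a weaker inhibitor, a lower number a stronger inhibitor:
compound 1, `CCC(=O)Nc1ccc(S(=O)(=O)Oc2ccccc2I)cc1`, 8100 nM
compound 2, `CC(C)c1ccccc1OS(=O)(=O)c1ccc(NC(=O)CCl)cc1`, 2900 nM
compound 3, `O=C(CCl)Nc1ccc(S(=O)(=O)Oc2ccccc2I)cc1`, 2500 nM

Compound 3 gives the lowest number of the three, but its gap to compound 2 is within the scatter, so the two cannot be ordered; only compound 1 stands clearly apart, as the step of a 3.2-fold lower number from compound 1 to compound 3 (0.51 log units; beyond the scatter) shows. The other step, a 1.2-fold lower number from compound 2 to compound 3 (0.06 log units; within the scatter), changes the substituent on the aryl ester and moves nothing beyond the scatter.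

Compound 4, `CCCCCNC(=O)Nc1ccc(S(=O)(=O)Oc2ccccc2I)cc1`, differs from compound 3 in this way: pentylamino in place of chloromethyl on a carbonyl carbon. Of the measured steps, only a 3.2-fold lower number from compound 1 to compound 3 (0.51 log units; beyond the scatter) touches the same position, and it shows that swapping the chloro out of the acyl group costs a modest but real amount. The pentylamino group entering in compound 4 again carries no chloro, and compound 1, which likewise lacks it, sits at 8100 nM. Among the measured compounds shown here, the wider change to a urea has no precedent among the measured compounds, so the expectation rests on that one step alone.

Compound 4 is therefore expected to give a higher number than compound 3, by about a 3.6-fold higher number from compound 3 to compound 4 (0.56 log units; beyond the scatter). The estimate for compound 4 is 9000 nM, with a range from 3000 nM to 27000 nM.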

Compound 4, half-maximal inhibitory concentration: 5400 nM
Compound 4: the middle estimate sits 1.7-fold (0.22 log units) above what was measured, within the range that was stated.
By their numbers in this assay, from the lowest: compounds 3, 2, 4 and 1 (each within the scatter of the next, the first and the last beyond it).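

Swapping chloromethyl for pentylamino on the carbonyl carbon in this assay also moves the number beyond the scatter (a 2.2-fold higher number from compound 3 to compound 4 (0.33 log units; beyond the scatter)), so a second acyl replacement without chloro, this time one that makes a urea, separates from compound 3. Pentylamino and ethyl at this position cannot be ordered (a 1.5-fold lower number from compound 1 to compound 4 (0.18 log units; within the scatter)), so among compounds 1, 3 and 4 the chloromethyl group alone stands apart, with none of the three going against that reading, though three compounds are a narrow base. No evidence is available that accounts for the difference between these groups at this position.

A methyl or bromomethyl group on the same carbonyl carbon would help show whether the result follows the chloro atom or the whole chloromethyl group, while ethylamino, octylamino or cyclohexylamino would test whether the chain attached to the urea matters at all. Also open, going by these compounds, is whether pentylamino behaves the same way with isopropyl in place of iodo on the aromatic carbon, the substituent carried by compound 2.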